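The source may hold more compounds than are shown below. What is called first, only, known or untested is meant among the compounds shown, and "the series" means these compounds.

Measured in a functional assay on PC-3 cells (Homo sapiens) for inhibition, read by MTT assay, with stated times of 18 h and 4 h; on this read-out higher numbers stand for weaker inhibition and lower numbers for stronger inhibition
- compound 1 `CCCCCCCCOP(=O)(O)OCCSC(=S)N1CCCCC1` reads > 100000 nM (a limit of the assay, not a number)
- compound 2 `CCCCCCCCCCCCCCCCOP(=O)(O)OCCSC(=S)N1CCN(C)CC1` reads 95200 nM
- compound 3 `CCCCCCCCCCOP(=O)(O)OCCSC(=S)N1CCCCC1` reads 62500 nM

Among the compounds with values here, compound 3 lies within the scatter of compound 2, and these are the only two actual numbers. Compound 4 `CCCCCCCCCCCCCCCCOP(=O)(O)OCCSC(=S)N1CCCCC1` differs from compound 3 by hexyl in place of hydrogen on a saturated chain carbon, ten or more bonds along the chain from an oxygen on an unsaturated carbon. Within the data shown here, one measured step bears on this change to the chain, an at least 1.6-fold lower number from compound 1 to compound 3 (0.20 log units; that floor lies within the scatter), and it rests on a limit. Compound 4 shares the chain of compound 2, and compound 2 gives 95200 nM, so no large drop is expected. The expected change in this assay is small, toward a lower number and not beyond the scatter: a 1.6-fold lower number from compound 3 to compound 4 (0.19 log units; within the scatter). Compound 4 is estimated at 40000 nM, with an expected range of 12000 nM to 100000 nM.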

Compound 4, half-maximal inhibitory concentration: 34300 nM
Compound 4: middle estimate off by 1.2-fold (0.07 log units), on the high side, and the stated range covers the measured number.
By their numbers in this assay, from the lowest: compounds 4, 3 and 2 (each within the scatter of the next, the first and the last beyond it). At a limit, above all of these: compound 1.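

In this assay, hexyl in place of hydrogen on this saturated chain carbon gives a 1.8-fold lower number from compound 3 to compound 4 (0.26 log units; within the scatter), so this lengthening of the chain does not clear the scatter. With the chain held the same, piperidin-1-yl in place of 4-methylpiperazin-1-yl on a thiocarbonyl carbon gives a 2.8-fold lower number from compound 2 to compound 4 (0.44 log units; beyond the scatter), the first step shown that clears it. Octyl in place of hydrogen gives an at least 2.9-fold lower number from compound 1 to compound 4 (0.46 log units; beyond the scatter), which is only a floor, set by a limit: the limit of > 100000 nM in this assay, at which 1 of the 4 values shown sits.

As far as these compounds go, whether a longer chain would lower the number further stays open. So does the effect of a morpholine or a diethylamino group on the thiocarbonyl carbon.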